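Methoxy to fluoro: a step beyond the assay edge

The compounds below may be only part of what the source reports. "The series", "measured", "known", "first", "only" and "open" are said of these compounds alone.

Compound 1 `COc1ccccc1-c1ccc(S(=O)(=O)N2CCC(N3CCC(C)CC3)CC2)cc1` gives > 5000 nM in an ADME assay on HCT-116 cells (Homo sapiens) for cytotoxicity, read by CellTiter-Glo, with a stated time of 72 h; on this read-out higher numbers stand for weaker inhibition and lower numbers for stronger inhibition.
Compound 2 `Cc1cc(C)c(S(=O)(=O)N2CCC(N3CCC(c4ccccc4)CC3)CC2)c(C)c1` gives > 5000 nM.
Compound 3 `Cc1cc(C)c(S(=O)(=O)NC2CCC(N3CCC(C)CC3)CC2)c(C)c1` gives > 5000 nM.

Each of these values is a limit of this assay rather than a number: the measurement reached its upper edge without finding a half-maximal inhibitory concentration. Compound 1 therefore cannot be ranked against the other two; all three sit together at the limit of > 5000 nM in this assay, at which 3 of the 3 values shown sit, and nothing separates them.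

Compound 4 `CC1CCN(C2CCN(S(=O)(=O)c3ccc(-c4ccccc4F)cc3)CC2)CC1` has not yet been measured in this assay. It differs from compound 1 in a single place: fluoro in place of methoxy on an aromatic carbon. For the measured compounds named here, no pair of measured compounds shows the effect of such a change, so no measured step can guide the expectation.

What can be said is this: because compound 1 gives > 5000 nM, and the two other measured compounds also end at a limit, the expected step from compound 1 to compound 4 is none beyond the scatter, and the estimated step that the limit leaves unreadable from compound 1 to compound 4 is expected to remain small. Compound 4 is therefore estimated at 8000 nM, with a range from 3000 nM to 30000 nM, and it is expected most likely to be reported again only as a limit.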

Compound 4, half-maximal inhibitory concentration: > 5000 nM
Compound 4: only a limit was reported (the forecaster's own chance of this, stated with the estimate: 80%); the middle value is on the limit's open side.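

In this assay compound 4 gives > 5000 nM, which is a limit and not a number. For the compounds shown here, compound 1 also ends at a limit, so no step from compound 1 to compound 4 can be read. All the compounds shown stop at one edge: the limit of > 5000 nM in this assay, at which 4 of the 4 values shown sit. On these data alone, what stays open is how far past that edge each compound lies, and so whether fluoro in place of methoxy changes anything.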